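Compound 3: replacing the methylcarbamoyl group of compound 1

A few compounds are considered here, and "the series" means these few. Any claim that something is new, unique, unknown or untested is made for them only; others in the source may bear on it.

In a functional assay on the whole organism with Mus musculus as the target (on this read-out higher numbers stand for an effect only at larger amounts of compound and lower numbers for an effect already at smaller amounts), compound 1 `CC[C@@H](C(=O)NC)N1CCCC1=O` gives 1800 umol/kg. Compound 2 `CC[C@@H](C(=O)N(C)OC)N1CCCC1=O` gives 1000 umol/kg, so the two values lie within the scatter of each other. Compound 3 `CC[C@@H](C(=N)S)N1CCCC1=O` differs from compound 1 as follows: a group of 3 heavy atoms (1 carbon, 1 nitrogen, 1 sulfur; no ring) in place of a group of 4 heavy atoms (2 carbon, 1 nitrogen, 1 oxygen; no ring), on a saturated chain carbon bound to an amide-type nitrogen in a ring and a saturated chain carbon. Within the data shown here, the only measured step, a 1.8-fold lower number from compound 1 to compound 2 (0.26 log units; within the scatter), alters the amide-type nitrogen and does not replace the whole methylcarbamoyl group, so it is a weak guide. Among the measured compounds shown here, no measured step covers this replacement, and a modest move to a lower number is expected, with wide uncertainty. The expected step is a 2.3-fold lower number from compound 1 to compound 3 (0.35 log units; beyond the scatter). For compound 3 the estimated value is 800 umol/kg, with an expected range of 100 umol/kg to 2500 umol/kg.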

Compound 3, dose for half-maximal effect: 1000 umol/kg
Beside the measured number, compound 3's estimate is 1.3-fold (0.10 log units) below it; low and high end bracket the measured number.
By their numbers in this assay, from the lowest: compounds 2, 3 and 1 (each within the scatter of the next).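

Within this assay the exchange of the whole methylcarbamoyl group, on a saturated chain carbon bound to an amide-type nitrogen in a ring and a saturated chain carbon, gives a 1.8-fold lower number from compound 1 to compound 3 (0.26 log units; within the scatter) and thus no separable change, whereas the earlier pair altered only the amide-type nitrogen. This place therefore accepts a group of 3 heavy atoms carrying sulfur with the number staying within the scatter. No available evidence accounts for this result.
On these data alone, whether a carboxylic acid, an amine or a longer chain on this carbon would give a step beyond the scatter remains open.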